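Changing the Ring on the Sulfonyl Sulfur: Compound 4

The source may hold more compounds than are shown below. What is called first, only, known or untested is meant among the compounds shown, and "the series" means these compounds.

Compound 1 `Cc1ccc2ncc(S(=O)(=O)c3ccc(F)cc3)c(N3CCC(C)CC3)c2c1` gives 90% in an assay on isolated protein for displacement of a labelled ligand from metabotropic glutamate receptor 5 (Homo sapiens), with a stated time of 60 min, tested at 1 uM; a lower number here means less inhibition, a higher number more inhibition at the concentration tested (going by the name of the read-out).
Compound 2 `Cc1ccc2ncc(S(=O)(=O)c3ccc(Cl)cc3)c(N3CCC(C)CC3)c2c1` gives 79% in this assay.
Compound 3 `Cc1ccc(S(=O)(=O)c2cnc3ccc(C)cc3c2N2CCC(C)CC2)cc1` gives 82% in this assay.

Compound 3 stands second highest of these three numbers, but both of its neighbours lie within the scatter: a number 3 percentage points higher from compound 2 to compound 3 (within the scatter) and a number 8 percentage points lower from compound 1 to compound 3 (within the scatter). Compound 4 `COc1ccc(S(=O)(=O)c2cnc3ccc(C)cc3c2N2CCC(C)CC2)cc1Cl` differs from compound 3 in one place: 3-chloro-4-methoxyphenyl in place of 4-methylphenyl on a sulfonyl sulfur. For the measured compounds named here, the one step that bears on this is the exchange of halogens, a number 11 percentage points lower from compound 1 to compound 2 (beyond the scatter), a modest loss, while a number 3 percentage points higher from compound 2 to compound 3 (within the scatter) showed no real difference. Going by the values given here, no measured step introduces a methoxy, so that part of the change is unknown. A small loss or none beyond the scatter is therefore expected for compound 4, a number 8 percentage points lower from compound 3 to compound 4 (within the scatter). Compound 4 is estimated at 74%, between 55% and 90%.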

Compound 4, a percentage reported as inhibition, at one concentration (the size of the read-out at that concentration, not a potency): 93%
Compound 4: the middle estimate sits 19 percentage points below what was measured; the measured number lies above the stated range.
By their numbers in this assay, from the lowest: compounds 2, 3, 1 and 4 (each within the scatter of the next, the first and the last beyond it).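

On a sulfonyl sulfur, 3-chloro-4-methoxyphenyl does not cost inhibition in this assay: it improves on 4-methylphenyl (a number 11 percentage points higher from compound 3 to compound 4 (beyond the scatter)) and on 4-chlorophenyl (a number 14 percentage points higher from compound 2 to compound 4 (beyond the scatter)). Against 4-fluorophenyl no real difference appears (a number 3 percentage points higher from compound 1 to compound 4 (within the scatter)), so a methoxy together with a chloro is accepted here. No measurement shown accounts for these steps. From the compounds shown here alone, the chloro and the methoxy enter together, so their separate shares remain open. Also open, going by these compounds, is how an amine or a carboxylic acid on this phenyl ring would fare.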